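The compounds below may be only part of what the source reports. "The series", "measured", "known", "first", "only" and "open" are said of these compounds alone.

Series notes on cytotoxicity. In a functional assay on HCC1599 cells (Homo sapiens) for cytotoxicity, read by luminescence and CellTiter-Glo, with a stated time of 24 h (on this read-out higher numbers stand for weaker inhibition and lower numbers for stronger inhibition), compound 1 `C=C1C[C@]23C[C@@]1(O)CC[C@H]2c1cc2c(C(=O)O)coc2c(C)c1[C@@H]3C(=O)O` is reported only as the limit > 10000 nM. Compound 2 `C=C1C[C@]23C[C@@]1(O)CC[C@H]2c1ccc(O/C=C/C(=O)OC)c(C)c1[C@@H]3C(=O)OC` in this assay likewise returns only the limit > 10000 nM. Compound 3 `C=C1C[C@]23C[C@@]1(O)CC[C@H]2[C@@]12C=C[C@H](O)[C@@](C)(C(=O)O1)[C@H]2[C@@H]3C(=O)OC` in this assay also returns only the limit > 10000 nM. Compound 3 therefore stands with the other two at the limit of > 10000 nM in this assay, at which 3 of the 3 values shown sit, and no ordering among the three can be read from these figures. Compound 4 `C=C1[C@@H](O)[C@]23C[C@@]1(O)CC[C@H]2[C@@]12C=C[C@H](O)[C@@](C)(C(=O)O1)[C@H]2[C@@H]3C(=O)OC` is the next member to be tested; it differs from compound 3 as follows: hydroxy in place of hydrogen on a saturated ring carbon. Going by the values given here, no measured step covers this kind of change, so the step expected here is a step that the limit leaves unreadable from compound 3 to compound 4, none beyond the scatter, and a limit rather than a number is again the most likely outcome. Compound 4 is accordingly estimated in this assay at 15000 nM, within 5000 nM to 40000 nM.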

Compound 4, half-maximal inhibitory concentration: > 10000 nM
Compound 4 ended at the assay's limit; the forecaster's own chance of this, stated with the estimate: 80%; the middle value does not contradict the limit.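

No step can be read from compound 3 to compound 4, since both values are limits only: the limit of > 10000 nM in this assay, at which 4 of the 4 values shown sit. The compounds shown leave open whether any change to the shared core gives a measurable value in this assay.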